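The source may report more compounds than this note shows. Statements on the series, on what has been measured and on what is new or still open speak of the compounds shown alone.

Compound 1: `O=C(O)CCc1ccc(C#Cc2ccccc2)cc1`, in a functional assay on 1321-N1 cells for agonist activity at Free fatty acid receptor 1 (Homo sapiens), read by calcium flux (a lower number here means that less compound is needed, a higher number that more compound is needed for the effect), compound 1 gives 200 nM.
Compound 2: `O=C(O)CCc1ccc(OCc2ccccc2Br)cc1`, in this assay compound 2 gives 447 nM.
Compound 3: `O=C(O)CCc1ccc(NCc2cccc(C(F)(F)F)c2)cc1`, in this assay compound 3 gives 186 nM.

Three compounds share a core carrying a propanoic acid chain, and they differ in the tail attached to it. Compound 3 has the lowest number of the three, but its gap to compound 1 lies within the scatter, so the two cannot be told apart; only compound 2 is set apart from compound 3, beyond the scatter.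

Compound 4, `Cc1ccc(-c2cccc(CNc3ccc(CCC(=O)O)cc3)c2)cc1`, has not yet been measured. It is built from compound 3 by a single change: 4-methylphenyl in place of trifluoromethyl on an aromatic carbon. The trifluoromethyl is removed and a 4-methylphenyl, a whole additional aromatic ring, takes its place on the same aromatic carbon, meta to a large group. Within the data shown here, no measured pair in this set isolates such a change, so there is no directly comparable step to lean on. The tail becomes longer, and the expected step from compound 3 to compound 4 is a moderate drop in the number, larger than the scatter but not by a great deal: a 2.3-fold lower number from compound 3 to compound 4 (0.37 log units; beyond the scatter) is what is anticipated. Compound 4 is therefore estimated at 80 nM, with a range from 20 nM to 400 nM.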

Compound 4, half-maximal effective concentration: 126 nM
For compound 4 the middle estimate is 1.6-fold (0.20 log units) below the measured one, within the range that was stated.
By their numbers in this assay, from the lowest: compounds 4, 3 and 1 (each within the scatter of the next); then compound 2.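

In this assay, putting 4-methylphenyl in place of trifluoromethyl on this aromatic carbon gives a 1.5-fold lower number from compound 3 to compound 4 (0.17 log units; within the scatter), so the two compounds cannot be told apart. Among these compounds, this is the first direct look at this position, since the earlier compounds differed from one another in more than one place and offered no such matched pair. It shows that a group of 7 heavy atoms carrying a whole aromatic ring can replace one of 4 heavy atoms with no ring at this carbon, meta to a large group, without a readable shift in the number, although nothing here accounts for that outcome.

A single pair cannot show whether the methyl on the new ring matters, so a plain phenyl would be the natural comparison, and a pyridine ring or a morpholine would test whether a ring containing nitrogen or oxygen fits here equally well. On these data alone, it also remains open whether a smaller group such as a chlorine or a methoxy at this carbon would give a similar number, or whether the same swap would behave alike on a tail joined through the ether link of compound 2.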